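Second methoxy on the aryl hydrazone: an expectation

The source may report more compounds than this note shows. Statements on the series, on what has been measured and on what is new or still open speak of the compounds shown alone.

Compound 1 `O=C(N/N=C/c1ccccc1)c1cccnc1Nc1cccc(C(F)(F)F)c1`: 31%
Compound 2 `COc1cccc(/C=N/NC(=O)c2cccnc2Nc2cccc(C(F)(F)F)c2)c1`: 14.9%

In a functional assay on the whole organism (strain Wistar) for inhibition, with Rattus norvegicus as the target, read by paw edema, with a stated time of 4 h, at a dose of 10 mg/kg by the intraperitoneal route (a lower number here means less inhibition, a higher number more inhibition at the dose given (going by the name of the read-out)), compound 2 gives the lower of the two numbers, and compound 1 gives the higher. Compound 3 `COc1ccc(/C=N/NC(=O)c2cccnc2Nc2cccc(C(F)(F)F)c2)cc1OC` differs from compound 2 by methoxy in place of hydrogen on an aromatic carbon. For the measured compounds named here, the one step that bears on this is a number 16.1 percentage points lower from compound 1 to compound 2 (beyond the scatter), the same kind of change on the same ring. A second methoxy is expected to lower the number again, though less, since the starting value is already low. The step expected here is a number 5.9 percentage points lower from compound 2 to compound 3 (within the scatter). Compound 3 is therefore estimated at 9%, within 0% to 22%.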

Compound 3, a percentage reported as inhibition, in the whole organism at one dose (the size of the read-out at that dose, not a potency): 52.9%
Compound 3: the middle estimate sits 43.9 percentage points below what was measured; measured number above the stated range.
By their numbers in this assay, from the lowest: compound 2; then compound 1; then compound 3.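

In this assay, the same change on the same ring does not always act the same way: placed ortho to a methoxy group and para to a large group, the methoxy gives a number 38 percentage points higher from compound 2 to compound 3 (beyond the scatter), against a number 16.1 percentage points lower from compound 1 to compound 2 (beyond the scatter) for the first methoxy. For the compounds shown here, the 3,4-dimethoxyphenyl group also ends higher than plain phenyl, with a number 21.9 percentage points higher from compound 1 to compound 3 (beyond the scatter), so the 3-methoxyphenyl result gave no guide to the pair. No evidence at hand accounts for this reversal.

Going by these compounds, whether the new methoxy would give the same number without the first one remains open. So does whether a hydroxyl or an amine in its place would read the same.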